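The source may hold more compounds than are shown below. What is called first, only, known or untested is meant among the compounds shown, and "the series" means these compounds.

Within the data shown here, in a functional assay on NCI-H460 cells (Homo sapiens) for inhibition, read by sulforhodamine B assay, with a stated time of 72 h (on this read-out higher numbers stand for weaker inhibition and lower numbers for stronger inhibition), compound 3 (`CCNC(=O)c1nnn(-c2cc(C(C)C)c(O)cc2O)c1-c1ccc(CN2CCC[C@@H](O)C2)cc1`) gives 52 nM, the only true number in this small set. Compound 1 (`CC(C)c1cc(-n2cc(-c3ccc(CN4CCN(c5ccccc5)CC4)cc3)nn2)c(O)cc1O`) gives > 1000 nM, which is a limit of the assay and not a number. Compound 2 (`CC(C)c1cc(-n2cc(-c3ccc(CN4CCN(Cc5ccccc5)CC4)cc3)nn2)c(O)cc1O`) gives > 1000 nM, which is also a limit. The one measured step among these compounds, a step that the two limits leave unreadable from compound 1 to compound 2, has no size to offer because of the limit of > 1000 nM in this assay, at which 2 of the 3 values shown sit. Among the measured compounds shown here, no measured step links either compound 1 or compound 2 to compound 3.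

Compound 4 (`CCNC(=O)c1nnn(-c2cc(C(C)C)c(O)cc2O)c1-c1ccc(CN2CCN(C)CC2)cc1`) differs from compound 3 by a single change, 4-methylpiperazin-1-yl in place of 3-hydroxypiperidin-1-yl on a saturated chain carbon bound to an aromatic carbon. The two groups are of equal heavy-atom count, and the data hold no readable step for this kind of exchange. No shift beyond the usual scatter is therefore expected in this assay, and the expectation starts from compound 3 at 52 nM, with a wide margin on either side. The expected change is a 1.2-fold higher number from compound 3 to compound 4 (0.06 log units; within the scatter). For compound 4 the estimated value is 60 nM, with an expected range of 20 nM to 180 nM.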

Compound 4, half-maximal inhibitory concentration: 47 nM
Estimate against measurement, compound 4: 1.3-fold (0.11 log units) above; low and high end bracket the measured number.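

In this assay, among these compounds, exchanging 3-hydroxypiperidin-1-yl for 4-methylpiperazin-1-yl on a saturated chain carbon bound to an aromatic carbon gives a 1.1-fold lower number from compound 3 to compound 4 (0.04 log units; within the scatter), the first step in this set with a readable size. Among the compounds shown here, the earlier compounds offered only a single true number and a step that could not be read, whereas this pair shows that the place accepts two different six-membered non-aromatic rings of equal heavy-atom count with no shift beyond the scatter, even though the hydrogen-bond donor and the defined stereocentre of 3-hydroxypiperidin-1-yl are absent from 4-methylpiperazin-1-yl. Nothing shown here gives a measured property that bears on this result.

The compounds shown leave open whether this holds for other groups at the same place, such as morpholine, an open-chain dimethylamino group or a carboxylic acid. For the compounds shown here, they also leave open what separates compound 3 and compound 4 from compound 1 and compound 2, which differ from them in more than one place and are linked to them by no single-change step.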